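Fluoro for Methyl on the Shared Core of Compound 2

A few compounds are considered here, and "the series" means these few. Any claim that something is new, unique, unknown or untested is made for them only; others in the source may bear on it.

Of the compounds shown here, three have been measured so far. Compound 1 `Cc1ccc(NC(=O)N[C@H](C)c2ccccc2)cc1` gives 98% in an ADME assay on the whole organism with Oryza sativa as the target, tested at 1 uM; a lower number here means a stronger effect, a higher number a weaker effect of the compound at the concentration tested. Compound 2 `Cc1ccc(NC(=O)N[C@@H](C)c2ccccc2)cc1` gives 99% in this assay, and compound 3 `CCCCCCCc1ccc(NC(=O)N[C@H](C)c2ccccc2)cc1` gives 100%. Compound 2 stands second highest of the three numbers, but both of its neighbours lie within the scatter: the step of a number 1 percentage points higher from compound 1 to compound 2 (within the scatter) and the step of a number 2 percentage points higher from compound 1 to compound 3 (within the scatter) are each small. The first of these two steps rests only on (the fact that compounds 1 and 2 differ only in the configuration as drawn); the second adds hexyl in place of hydrogen on a saturated chain carbon bound to an aromatic carbon.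

Compound 4 `C[C@H](NC(=O)Nc1ccc(F)cc1)c1ccccc1` has not yet been measured. Compared with compound 2 it differs as follows: fluoro in place of methyl on an aromatic carbon. Going by the values given here, no measured step exchanges one group for another on the aromatic ring, so the only guidance is that the three numbers so far all lie within the scatter of one another. Compound 4 is therefore expected to show a step of a number 1 percentage points lower from compound 2 to compound 4 (within the scatter), that is no change beyond the scatter. The estimate for compound 4 is 98%, with a range from 90% to 100%.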

Compound 4, a percentage reported as activity, at one concentration (the size of the read-out at that concentration, not a potency): 97%
The estimate for compound 4 lay 1 percentage points above the measured number; low and high end bracket the measured number.
By their numbers in this assay, from the lowest: compounds 4, 1, 2 and 3 (each within the scatter of the next).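

Fluoro in place of methyl on an aromatic carbon, para to a large group, gives in this assay a number 2 percentage points lower from compound 2 to compound 4 (within the scatter) and so adds the first exchange of one group for another at this position. The earlier compounds shown here showed only a longer chain there, with a number 2 percentage points higher from compound 1 to compound 3 (within the scatter) as the step, whereas compound 4 carries a group that is not a carbon chain and its number still stays within the scatter of compound 2. Nothing available gives a reason for this step.

Because each of the four numbers lies within the scatter of the next, the compounds shown do not tell whether any group at this position can move the number beyond the scatter. Going by these compounds, what an amine or a carboxylic acid in place of fluoro would give stays open, and so does whether the other configuration as drawn behaves alike with fluoro.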